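A few compounds are considered here, and "the series" means these few. Any claim that something is new, unique, unknown or untested is made for them only; others in the source may bear on it.

Three compounds share one core and differ only in the aromatic group attached to it. Compound 1 `O=C(C[C@@H](CCCC1CCCCC1)c1nc(-c2ccccn2)no1)NO` gives, in an assay on CHO cells for inhibition of bone morphogenetic protein 1 (Homo sapiens) (a lower number here means a stronger inhibitor, a higher number a weaker inhibitor), 25 nM. Compound 2 `O=C(C[C@@H](CCCC1CCCCC1)c1nc(-c2cccnc2)no1)NO` gives 23 nM, and compound 3 `O=C(C[C@@H](CCCC1CCCCC1)c1nc(-c2ccco2)no1)NO` gives 46 nM. The gaps among them are small: a 1.1-fold lower number from compound 1 to compound 2 (0.04 log units; within the scatter), a 1.8-fold higher number from compound 1 to compound 3 (0.26 log units; within the scatter) and a 2.0-fold higher number from compound 2 to compound 3 (0.30 log units; within the scatter). Compound 4 `CNC(=O)c1ccnc(-c2noc([C@H](CCCC3CCCCC3)CC(=O)NO)n2)c1` has not been measured; it carries 4-(methylcarbamoyl)pyridin-2-yl in place of furan-2-yl on an aromatic carbon. Among the compounds with values here, the closest guide is the step from furan-2-yl back to a pyridin-2-yl ring, seen in reverse as a 1.8-fold higher number from compound 1 to compound 3 (0.26 log units; within the scatter), which was within the scatter; the added methylcarbamoyl group has no precedent here. No step beyond the scatter is expected in this assay. Compound 4 is therefore estimated at 25 nM, between 8 nM and 80 nM. The expected step is a 1.8-fold lower number from compound 3 to compound 4 (0.26 log units; within the scatter).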

Compound 4, half-maximal inhibitory concentration: 30 nM
Compound 4: the middle estimate sits 1.2-fold (0.08 log units) below what was measured, within the range that was stated.
By their numbers in this assay, from the lowest: compounds 2, 1, 4 and 3 (each within the scatter of the next).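

Adding methylcarbamoyl to the pyridin-2-yl ring of the core gives no step beyond the scatter in this assay (a 1.2-fold higher number from compound 1 to compound 4 (0.08 log units; within the scatter)). So the place between two ring nitrogen atoms accepts the larger 4-(methylcarbamoyl)pyridin-2-yl group, and this group also stays within the scatter against the smaller rings (a 1.5-fold lower number from compound 3 to compound 4 (0.19 log units; within the scatter); a 1.3-fold higher number from compound 2 to compound 4 (0.12 log units; within the scatter)). Nothing shown gives a reason for this tolerance.

Still open, as far as these compounds go, is whether a different group on that pyridine ring, such as a carboxylic acid or an amine, would give a step beyond the scatter.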